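Ethyl ester in place of a free acid on a benzothiazole series

This account rests on a few compounds, and the source may have more. Where it says the series, first, only, none or still open, it means among the compounds named here.

Of the compounds shown here, three sharing one core have been measured in a functional assay on HepG2 cells (Homo sapiens) for inhibition, read by MTT assay, with a stated time of 3 days; a lower number here means a stronger inhibitor, a higher number a weaker inhibitor. Compound 1 `COc1cc(-c2nc3ccccc3s2)ccc1OCC(=O)NNC(=O)CN[C@@H](CCSC)C(=O)O` gives 3780 nM, and compound 3 `CCOC(=O)[C@H](CCSC)NCC(=O)NNC(=O)COc1ccc(-c2nc3ccccc3s2)cc1OC` gives 3330 nM. The change between them, (ethyl in place of hydrogen on an oxygen next to a carbonyl group), made a step of a 1.1-fold lower number from compound 1 to compound 3 (0.06 log units; within the scatter). Compound 2 `COc1cc(-c2nc3ccccc3s2)ccc1OCC(=O)NNC(=O)CNC(=N)NCCC[C@H](N[N+](=O)[O-])C(=O)O` gives 3490 nM in this assay; how its core differs from that of compound 1 is not broken down here. Compound 4 `CCOC(=O)[C@H](CCCNC(=N)NCC(=O)NNC(=O)COc1ccc(-c2nc3ccccc3s2)cc1OC)N[N+](=O)[O-]` is not yet measured. It differs from compound 2 by ethyl in place of hydrogen on an oxygen next to a carbonyl group, the same change as that from compound 1 to compound 3. Because that earlier step was a 1.1-fold lower number from compound 1 to compound 3 (0.06 log units; within the scatter), the step expected here is a 1.1-fold lower number from compound 2 to compound 4 (0.04 log units; within the scatter), resting on that single pair alone. Compound 4 is therefore estimated at 3200 nM in this assay, expected to fall between 1600 nM and 6500 nM.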

Compound 4, half-maximal inhibitory concentration: 3730 nM
For compound 4 the middle estimate is 1.2-fold (0.07 log units) below the measured one, and the stated range covers the measured number.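

In this assay, ethyl in place of hydrogen on an oxygen next to a carbonyl group gave a 1.1-fold higher number from compound 2 to compound 4 (0.03 log units; within the scatter) on the second core. Set beside the earlier pair, the change reads alike on both cores, with no step beyond the scatter on either: the same change on two cores in this assay, a 1.1-fold lower number (0.06 log units; within the scatter) from compound 1 to compound 3 and a 1.1-fold higher number (0.03 log units; within the scatter) from compound 2 to compound 4, 1.2-fold (0.08 log units) apart, within the scatter of two such steps. This shows that, across these two pairs, the free acid and the ethyl ester cannot be told apart in this assay, but it does not show that the same would hold on any other core, and the two steps give no direction that can be read.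

The compounds shown leave open how a methyl ester, a primary amide or a longer chain on that oxygen would read in this assay. They also leave open whether the change would behave alike on a core carrying a different amino acid side chain.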